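Three Dihydropyrimidine Amides and a Fourth Awaiting Its Number

A few compounds are considered here, and "the series" means these few. Any claim that something is new, unique, unknown or untested is made for them only; others in the source may bear on it.

Compound 1 `CC1=C(C(=O)Nc2ccc([N+](=O)[O-])cc2)C(c2ccc(Br)cc2)N=C(SCc2ccccc2Cl)N1`: 1.5%
Compound 2 `CC1=C(C(=O)Nc2ccc([N+](=O)[O-])cc2)C(c2ccc(Br)cc2)N=C(SCc2cccc(Cl)c2)N1`: 2.1%
Compound 3 `CC1=C(C(=O)Nc2ccc([N+](=O)[O-])cc2)C(c2cccc([N+](=O)[O-])c2)N=C(SCc2ccccc2Cl)N1`: 2.1%

All three were tested in a functional assay on the whole organism (artery, strain albino) with Rattus norvegicus as the target, with a stated time of 15 min, at a dose of 10 mg/kg by the oral route; a lower number here means less inhibition, a higher number more inhibition at the dose given (going by the name of the read-out). The cores of compound 1 and compound 3 differ by 3-nitrophenyl in place of 4-bromophenyl on a saturated ring carbon, a change that gave a number 0.6 percentage points higher from compound 1 to compound 3 (within the scatter). Compound 2 differs from compound 1 by 3-chlorophenyl in place of 2-chlorophenyl on a saturated chain carbon bound to a sulfur, which gave a number 0.6 percentage points higher from compound 1 to compound 2 (within the scatter). Compound 4 `CC1=C(C(=O)Nc2ccc([N+](=O)[O-])cc2)C(c2cccc([N+](=O)[O-])c2)N=C(SCc2cccc(Cl)c2)N1` carries the same change, made on compound 3 instead: 3-chlorophenyl in place of 2-chlorophenyl on a saturated chain carbon bound to a sulfur, at the same place in both pairs. Because the earlier step was a number 0.6 percentage points higher from compound 1 to compound 2 (within the scatter), the step for compound 4 is expected to be about as small, a number 0.6 percentage points higher from compound 3 to compound 4 (within the scatter), an expectation resting on two compounds only. For compound 4 in this assay the estimated read-out is 2.7%, expected to fall between -5% and 10%.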

Compound 4, a percentage reported as inhibition, in the whole organism at one dose (the size of the read-out at that dose, not a potency): 2.6%
The estimate for compound 4 lay 0.1 percentage points above the measured number; low and high end bracket the measured number.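

The 3-chlorophenyl change carried over from one core to the other: the same change on two cores in this assay, a number 0.6 percentage points higher (within the scatter) from compound 1 to compound 2 and a number 0.5 percentage points higher (within the scatter) from compound 3 to compound 4, 0.1 percentage points apart, within the scatter of two such steps

The 3-nitrophenyl change did the same: the same change on two cores in this assay, a number 0.6 percentage points higher (within the scatter) from compound 1 to compound 3 and a number 0.5 percentage points higher (within the scatter) from compound 2 to compound 4, 0.1 percentage points apart, within the scatter of two such steps

In this assay, the new steps, a number 0.5 percentage points higher from compound 3 to compound 4 (within the scatter) and a number 0.5 percentage points higher from compound 2 to compound 4 (within the scatter), are both small; this agreement shows that neither change shifted the read-out on these cores, but it does not show that a change with a real effect would carry over in the same way.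

The compounds shown leave open what a longer chain or an amine would do in place of the chlorophenyl on the saturated chain carbon bound to a sulfur. They also leave open what a carboxylic acid on the phenyl group at the saturated ring carbon would do.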